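The source may report more compounds than this note shows. Statements on the series, on what has been measured and on what is new or still open speak of the compounds shown alone.

Going by the values given here, in a functional assay on A549 cells (Homo sapiens) for inhibition (on this read-out higher numbers stand for weaker inhibition and lower numbers for stronger inhibition), compound 1 `C=CCOC(=O)Nc1nc(=O)n(C2O[C@H](C(=O)O)[C@@H](O)[C@H]2O)cc1F` gives 0.04 ug/mL, while compound 2 `C#CCOC(=O)Nc1nc(=O)n(C2O[C@H](C(=O)O)[C@@H](O)[C@H]2O)cc1F` gives 0.005 ug/mL, the lower of only two numbers and therefore the stronger inhibition. Among the compounds with values here, the single measured step, an 8.0-fold lower number from compound 1 to compound 2 (0.90 log units; beyond the scatter), replaced vinyl with ethynyl on the saturated chain and was modest but beyond the scatter. Compound 3 `O=C(Nc1nc(=O)n(C2O[C@H](C(=O)O)[C@@H](O)[C@H]2O)cc1F)Oc1ccccc1` makes a larger change to the same part of compound 2: phenyl in place of propargyl on an oxygen next to a carbonyl group. Within the data shown here, no measured compound carries phenyl, so the one step offers only a rough guide to size. With compound 2 at the low end, a rise is expected, similar in size to that measured step. The estimated change is a 6.0-fold higher number from compound 2 to compound 3 (0.78 log units; beyond the scatter), meaning weaker inhibition. For compound 3 the expected value is 0.03 ug/mL, with an estimated range of 0.005 ug/mL to 0.2 ug/mL.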

Compound 3, half-maximal inhibitory concentration: 0.55 ug/mL
Compound 3: middle estimate off by 18-fold (1.26 log units), on the low side; the whole stated range lies below it.
By their numbers in this assay, from the lowest: compound 2; then compound 1; then compound 3.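

In this assay, putting phenyl on the oxygen next to a carbonyl group gives a 110-fold higher number from compound 2 to compound 3 (2.04 log units; beyond the scatter) and, against the allyl compound, a 14-fold higher number from compound 1 to compound 3 (1.14 log units; beyond the scatter). This position can therefore shift the number much further than the earlier change at the end of the chain suggested, an 8.0-fold lower number from compound 1 to compound 2 (0.90 log units; beyond the scatter), and among these three compounds the two open chains, allyl and propargyl, both give stronger inhibition than phenyl. Nothing available here accounts for the weaker inhibition with phenyl.

Phenyl differs from propargyl both in having a ring and in its larger count of heavy atoms, so the compounds shown leave open which of the two matters. As far as these compounds go, it also remains open where a longer open chain, such as butyl, would fall in this order.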